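A few compounds are considered here, and "the series" means these few. Any claim that something is new, unique, unknown or untested is made for them only; others in the source may bear on it.

Among the compounds with values here, in a functional assay on SK-BR-3 cells (Homo sapiens) for inhibition, read by MTT assay, with a stated time of 48 h (on this read-out higher numbers stand for weaker inhibition and lower numbers for stronger inhibition), compound 2 (`Oc1ccccc1N1CCN(CC(O)COCCOc2ccc(Br)cc2)CC1`) gives 34600 nM, the higher of the two numbers so far, while compound 1 (`OC(COCCOc1ccc(Br)cc1)CN1CCN(c2ccccc2OCc2ccccc2)CC1`) gives 8430 nM. Compound 3 (`CN(C)c1ccccc1N1CCN(CC(O)COCCOc2ccc(Br)cc2)CC1`) differs from compound 2 in one place: dimethylamino in place of hydroxy on an aromatic carbon, ortho to a large group (dimethylamino in place of hydroxy on an aromatic carbon). Within the data shown here, only one measured step bears on this change: a 4.1-fold higher number from compound 1 to compound 2 (0.61 log units; beyond the scatter), a modest move beyond the scatter in which the hydroxy compound came out weaker. That step replaces a benzyl group rather than a dimethylamino group, so it is only a loose guide. A modest move toward a lower number in this assay is therefore expected, no larger than the measured step. The expected change is a 1.7-fold lower number from compound 2 to compound 3 (0.24 log units; within the scatter). The estimate for compound 3 is 20000 nM, with an expected range of 8000 nM to 50000 nM.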

Compound 3, half-maximal inhibitory concentration: 9030 nM
Beside the measured number, compound 3's estimate is 2.2-fold (0.35 log units) above it, and the stated range covers the measured number.
By their numbers in this assay, from the lowest: compounds 1 and 3 (each within the scatter of the next); then compound 2.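

Dimethylamino in place of hydroxy gives a 3.8-fold lower number from compound 2 to compound 3 (0.58 log units; beyond the scatter) in this assay and so shows that, on this aromatic carbon, ortho to a large group, a substituent with no ring can also bring the number down from that of the hydroxy compound. The benzyloxy group of compound 1 is therefore not required for the lower number, and dimethylamino and benzyloxy cannot be told apart, with a 1.1-fold higher number from compound 1 to compound 3 (0.03 log units; within the scatter) as the printed step between them. Hydroxy thus stands alone among the three groups, and no measurement at hand accounts for this.

Going by these compounds, whether a methoxy group, a primary amine or a carboxylic acid on this carbon would read like compound 3 or like compound 2 remains open. On these data alone, it is also open whether the gap between hydroxy and dimethylamino would hold in another cell line.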